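A few compounds are considered here, and "the series" means these few. Any claim that something is new, unique, unknown or untested is made for them only; others in the source may bear on it.

Three compounds share one core and differ only in the group carried on an aromatic nitrogen. Compound 1 `CCc1ccc(-n2nc(-c3ccc(C(F)(F)F)cc3O)nc2-c2ccccc2O)cc1` gives 64.4% in a functional assay on PC-12 cells (Rattus norvegicus) for cytotoxicity, read by MTT assay, with stated times of 2 h and 24 h, tested at 1 uM (a higher number here means a stronger effect of the compound at the concentration tested, a lower number a weaker effect), compound 2 `CC(C)c1ccc(-n2nc(-c3ccc(C(F)(F)F)cc3O)nc2-c2ccccc2O)cc1` gives 69.7%, and compound 3 `COc1ccccc1-n1nc(-c2ccc(C(F)(F)F)cc2O)nc1-c1ccccc1O` gives 70.7%. Compound 3 has the highest of the three numbers, yet the gaps a number 6.3 percentage points higher from compound 1 to compound 3 (within the scatter) and a number 1 percentage points higher from compound 2 to compound 3 (within the scatter) lie within the scatter, as does a number 5.3 percentage points higher from compound 1 to compound 2 (within the scatter). Compound 4 `COc1cccc(-n2nc(-c3ccc(C(F)(F)F)cc3O)nc2-c2ccccc2O)c1` differs from compound 3 by 3-methoxyphenyl in place of 2-methoxyphenyl on an aromatic nitrogen. The two steps that bear on this change are the replacements on the same aromatic nitrogen, and neither moved the number beyond the scatter. The same is expected here, a step of a number 1.7 percentage points lower from compound 3 to compound 4 (within the scatter) that stays within the scatter. Compound 4 is estimated at 69%, within 59% to 79%.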

Compound 4, a percentage reported as activity, at one concentration (the size of the read-out at that concentration, not a potency): 68.3%
For compound 4 the middle estimate is 0.7 percentage points above the measured one; the range from low to high includes it.
By their numbers in this assay, from the lowest: compounds 1, 4, 2 and 3 (each within the scatter of the next).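

In this assay, for the compounds shown here, the earlier steps exchanged one group on the aromatic nitrogen for a different one, whereas 3-methoxyphenyl in place of 2-methoxyphenyl keeps the same atoms joined differently and still gives only a number 2.4 percentage points lower from compound 3 to compound 4 (within the scatter). The exchanges for the alkylphenyl groups agree, with a number 1.4 percentage points lower from compound 2 to compound 4 (within the scatter) and a number 3.9 percentage points higher from compound 1 to compound 4 (within the scatter), so no replacement among these four compounds leaves the scatter. Nothing available gives a reason for this result. The compounds shown leave open whether an amine or a carboxylic acid on this phenyl ring would move the number beyond the scatter.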